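The source may hold more compounds than are shown below. What is called first, only, known or untested is meant among the compounds shown, and "the series" means these compounds.

In a physicochemical assay for solubility, read by spectrophotometry (on this read-out higher numbers stand for higher solubility and lower numbers for lower solubility), compound 1 `O=C(COc1ccc(-c2cc(=O)c3c(O)c(O)c(O)cc3o2)cc1)N1CCOCC1` gives 9.45 ug/mL and compound 2 `CN(C)CCCOc1ccc(-c2cc(=O)c3c(O)c(O)c(O)cc3o2)cc1` gives 8.5 ug/mL, so compound 2 stands within the scatter of compound 1. Compound 3 `O=C(Oc1ccc(-c2cc(=O)c3c(O)c(O)c(O)cc3o2)cc1)N1CCOCC1` is reached from compound 2 by one change, (morpholin-4-yl)carbonyl in place of 3-(dimethylamino)propyl on an oxygen on an aromatic ring. Going by the values given here, only one measured step bears on this. Exchanging (morpholin-4-yl)carbonyl for 2-(dimethylamino)ethyl on a saturated chain carbon bound to an oxygen on an aromatic ring gave a 1.1-fold lower number from compound 1 to compound 2 (0.05 log units; within the scatter). Among the compounds with values here, that step is only a partial guide, since no measured compound carries (morpholin-4-yl)carbonyl directly on the oxygen. No shift beyond the scatter is therefore expected in this assay, and no direction can be favoured. The expected step is a 1.1-fold higher number from compound 2 to compound 3 (0.02 log units; within the scatter). Compound 3 is estimated at 9 ug/mL, with an expected range of 4.5 ug/mL to 18 ug/mL.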

Compound 3, solubility: 15.3 ug/mL
For compound 3 the middle estimate is 1.7-fold (0.23 log units) below the measured one; the range from low to high includes it.
By their numbers in this assay, from the lowest: compounds 2, 1 and 3 (each within the scatter of the next).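

Compound 3 puts (morpholin-4-yl)carbonyl on the oxygen on an aromatic ring itself, and this assay still gives no step beyond the scatter by either route (a 1.8-fold higher number from compound 2 to compound 3 (0.26 log units; within the scatter)) (a 1.6-fold higher number from compound 1 to compound 3 (0.21 log units; within the scatter)). Across these compounds, then, this oxygen has carried 3-(dimethylamino)propyl, ((morpholin-4-yl)carbonyl)methyl and (morpholin-4-yl)carbonyl without any listed pair separating beyond the scatter, and the morpholine amide of compound 1 and the morpholine carbamate of compound 3 read alike here. Nothing measured on these compounds accounts for the values.

As far as these compounds go, whether a carboxylic acid, a piperazine or a longer chain on this oxygen would move the read-out beyond the scatter stays open. So does whether the same holds for a free hydroxyl at this place in this assay.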